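Halogen change on the para position of the pendant phenyl

A few compounds are considered here, and "the series" means these few. Any claim that something is new, unique, unknown or untested is made for them only; others in the source may bear on it.

The series shares one core, seen in compound 1 `Nc1scc(-c2cccc(F)c2)c1C(=O)c1ccc(Cl)cc1` and compound 2 `Nc1scc(-c2ccc(Br)cc2)c1C(=O)c1ccc(Cl)cc1`. Among the compounds with values here, in a functional assay on CHO cells for agonist activity at adenosine receptor A1 (Homo sapiens), read by fluorescence and ERK phosphorylation, with stated times of 30 min and 1.5 h, tested at 10 uM (on this read-out higher numbers stand for a stronger effect at the one concentration tested and lower numbers for a weaker effect), compound 1 gives 90%, whereas compound 2 gives 46%; the only measured step, a number 44 percentage points lower from compound 1 to compound 2 (beyond the scatter), is 4-bromophenyl in place of 3-fluorophenyl. On these two numbers compound 2 stands lowest, and the gap to compound 1 lies beyond the scatter.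

Compound 3 `Nc1scc(-c2ccc(I)cc2)c1C(=O)c1ccc(Cl)cc1` is the next member. It differs from compound 2 as iodo in place of bromo on an aromatic carbon. Within the data shown here, no measured step covers an exchange of one halogen for another at this carbon; the step from compound 1 to compound 2 changed both the halogen and its position, so it does not bear directly on this one. With nothing directly comparable, the expectation for compound 3 in this assay is a number close to that of compound 2, estimated as 42% within 20% to 65%, a step of a number 4 percentage points lower from compound 2 to compound 3 (within the scatter) that is expected to stay within the scatter.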

Compound 3, a percentage reported as activity, at one concentration (the size of the read-out at that concentration, not a potency): 61%
Compound 3: middle estimate off by 19 percentage points, on the low side; the measured number falls inside the stated range.
By their numbers in this assay, from the lowest: compound 2; then compound 3; then compound 1.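

At the carbon para to a large group, the halogen alone moves the read-out in this assay: the exchange of bromo for iodo gives a number 15 percentage points higher from compound 2 to compound 3 (beyond the scatter), a change the earlier pair could not isolate, since it altered halogen and position together. The 4-iodophenyl group does not close the gap to the 3-fluorophenyl group, with a number 29 percentage points lower from compound 1 to compound 3 (beyond the scatter), so both 4-halophenyl compounds remain below compound 1 on the printed steps. No available evidence bears on the reason for either step.

Still open, as far as these compounds go, is whether the remaining gap to compound 1 follows from the halogen or from its position, a question that 4-fluorophenyl and 3-iodophenyl groups would separate. Also open, from the compounds shown here alone, is how an amine or a carboxylic acid would read at this carbon.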